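The source may hold more compounds than are shown below. What is called first, only, known or untested is meant among the compounds shown, and "the series" means these compounds.

In a functional assay on A-431 cells (Homo sapiens) for cytotoxicity, read by MTT assay, with a stated time of 72 h, tested at 1 uM (a higher number here means more inhibition of growth at the concentration tested, a lower number less inhibition of growth), compound 2 `Cc1cccc(/C(N)=N/NC(=S)N2CCCCC2)n1` gives 35%, and compound 1 `Cc1cccc(/C(N)=N/NC(=S)N2CCSCC2)n1` gives 42.8%; the two numbers sit within the scatter of each other, so neither can be called the stronger. Within the data shown here, the only measured step, a number 7.8 percentage points lower from compound 1 to compound 2 (within the scatter), exchanged one saturated ring for another on the thiocarbonyl carbon and changed little. Compound 3 `Cc1cccc(/C(N)=N/NC(=S)N2CCCC2)n1` carries a further exchange of the same kind: pyrrolidin-1-yl in place of piperidin-1-yl on a thiocarbonyl carbon. Because that earlier step a number 7.8 percentage points lower from compound 1 to compound 2 (within the scatter) stayed within the scatter, the new step is expected to do the same, a number 2 percentage points higher from compound 2 to compound 3 (within the scatter). Compound 3 is therefore estimated at 37%, most likely between 22% and 52%.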

Compound 3, percent growth inhibition at one concentration: 21%
Beside the measured number, compound 3's estimate is 16 percentage points above it, outside the stated range (below it).
By their numbers in this assay, from the lowest: compound 3; then compounds 2 and 1 (each within the scatter of the next).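

Exchanging one ring for another on the thiocarbonyl carbon is therefore not always harmless. In this assay, pyrrolidin-1-yl brings a number 14 percentage points lower from compound 2 to compound 3 (beyond the scatter) and a number 21.8 percentage points lower from compound 1 to compound 3 (beyond the scatter), so this position can tell these rings apart, unlike the first step. Nothing available explains this loss of growth inhibition. Still open, going by these compounds, is how an open-chain diethylamino group or a larger azepan-1-yl ring would behave on the same carbon. Also open, on these data alone, is whether morpholin-4-yl would stay close to compound 1 or fall towards compound 3.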